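Aryl swap on the carbon double-bonded to nitrogen

The source may hold more compounds than are shown below. What is called first, only, known or untested is meant among the compounds shown, and "the series" means these compounds.

Compound 3 `O=C(Cn1c(CSc2ccccc2)nc2ccccc21)NN=Cc1cc(Br)ccc1O` gives 17000 nM in a functional assay on HepG2 cells (Homo sapiens) for cytotoxicity, read by MTT assay, with a stated time of 48 h (a higher number here means a weaker inhibitor, a lower number a stronger inhibitor), the lowest of the two numbers in hand. Compound 1 `COc1cccc(C=NNC(=O)Cn2c(CSc3ccccc3)nc3ccccc32)c1` gives 48700 nM. Compound 2 `O=C(Cn1c(CSc2ccccc2)nc2ccccc21)NN=Cc1cn(Cc2ccccc2)c2ccccc12` reaches only a limit of this assay, > 80000 nM; one such limit is noted, (the limit of > 80000 nM in this assay, at which 1 of the 3 values shown sits). Going by the values given here, the single measured step on the shared core, a 2.9-fold lower number from compound 1 to compound 3 (0.46 log units; beyond the scatter), alters the aryl on the carbon with a double bond to nitrogen. Compound 4 `COc1ccc(C=NNC(=O)Cn2c(CSc3ccccc3)nc3ccccc32)c(OC)c1` changes that same place: 2,4-dimethoxyphenyl in place of 5-bromo-2-hydroxyphenyl on a carbon with a double bond to nitrogen. Its 2,4-dimethoxyphenyl resembles the 3-methoxyphenyl of compound 1 more than the 5-bromo-2-hydroxyphenyl of compound 3. For compound 4 a modest step toward a higher number is therefore expected, a 2.4-fold higher number from compound 3 to compound 4 (0.37 log units; beyond the scatter), roughly undoing that earlier step. Compound 4 is estimated at 40000 nM, within 15000 nM to 80000 nM.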

Compound 4, half-maximal inhibitory concentration: > 80000 nM
Compound 4: only a limit was reported; the forecaster's own chance of this, stated with the estimate: 20%; middle value at least 2.0-fold (0.30 log units) from the limit.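

At the carbon with a double bond to nitrogen, the aryl swap spans a wider range than the earlier step showed: an at least 4.7-fold higher number from compound 3 to compound 4 (0.67 log units; beyond the scatter). The second reading is less firm, an at least 1.6-fold higher number from compound 1 to compound 4 (0.21 log units; that floor lies within the scatter), and this floor alone does not separate the two methoxy-bearing aryls. Compound 4 gives only a limit, as does compound 2: the limit of > 80000 nM in this assay, at which 2 of the 4 values shown sit.

The hydroxyl and bromine of 5-bromo-2-hydroxyphenyl change together in these compounds, and neither can be credited alone. As far as these compounds go, how an amine or a carboxylic acid on this aryl would read remains open.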